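A few compounds are considered here, and "the series" means these few. Any claim that something is new, unique, unknown or untested is made for them only; others in the source may bear on it.

Measured compounds:
compound 1, `O=C(Nc1ccccc1)c1cccc(Br)c1`: > 100000 nM
compound 2, `O=C(Nc1ccccc1)c1cc(Br)cc(Br)c1`: > 100000 nM
compound 3, `O=C(Nc1ccc(Sc2nc3ccccc3s2)cc1)c1ccccc1O`: > 100000 nM

Each of these three values is a limit of an assay for inhibition of HSP60/HSP10 (Homo sapiens), with a stated time of 60 min (on this read-out lower numbers stand for stronger inhibition and higher numbers for weaker inhibition), and not a number; (the limit of > 100000 nM in this assay, at which 3 of the 3 values shown sit). Compound 2 arises from compound 1 by bromo in place of hydrogen on an aromatic carbon, and the two limits leave the step that the two limits leave unreadable from compound 1 to compound 2 unreadable. Compound 4, `O=C(Nc1ccc(Sc2nc3ccccc3s2)cc1)c1cccc(Br)c1O`, is not yet measured in this assay. It arises from compound 3 by bromo in place of hydrogen on an aromatic carbon. The surroundings of the place are not the same: in compound 2 the entering bromo stands meta to a bromo group and meta to a group of 9 heavy atoms, whereas in compound 4 it stands ortho to a hydroxy group and meta to a large group, so this is the same kind of change, not the same change. The difference between the core of compound 1 and the core of compound 3 is not broken down here. Within the data shown here, since the one earlier step of this kind is unreadable, and compound 3 itself gives only a limit, the expected step in this assay is a step that the limit leaves unreadable from compound 3 to compound 4. Compound 4 is estimated at 150000 nM, between 30000 nM and 500000 nM, most likely again a limit.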

Compound 4, half-maximal inhibitory concentration: 26000 nM
Compound 4: middle estimate off by 5.8-fold (0.76 log units), on the high side; measured number outside the range, below it.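

In this assay, bromo in place of hydrogen on an aromatic carbon, ortho to a hydroxy group and meta to a large group, gives an at least 3.8-fold lower number from compound 3 to compound 4 (0.58 log units; beyond the scatter), so on the core of compound 3 the change brings a measurable number. Compound 3 gives > 100000 nM, which is a limit and not a number, so the step has a minimum size but no exact one. The result does not show that the change carries from one core to another, as the one earlier step of this kind, on the core of compound 1, cannot be read: the limit of > 100000 nM in this assay, at which 3 of the 4 values shown sit.

The compounds shown leave open whether chloro or methyl at the same place would lower the number as bromo does. They also leave open how far the step depends on the hydroxy group, which an amine or a methoxy group in its stead would test.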